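This account rests on a few compounds, and the source may have more. Where it says the series, first, only, none or still open, it means among the compounds named here.

In a functional assay on the whole organism for inhibition, with Mus musculus as the target (on this read-out higher numbers stand for an effect only at larger amounts of compound and lower numbers for an effect already at smaller amounts), two compounds with the same core have been measured so far. Compound 1 `CCOC(=O)Nc1cccc2c1CN(C)CC2c1ccccc1` gives 3.2 mg/kg, while compound 2 `CN1Cc2c(NC(=O)OCc3ccccc3)cccc2C(c2ccccc2)C1` gives about 15 mg/kg, the higher of the two numbers, so compound 2 needs the larger dose. For the measured compounds named here, the only measured step is a 4.7-fold higher number from compound 1 to compound 2 (0.67 log units; beyond the scatter), a modest one that comes with phenyl in place of methyl.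

Compound 3 `CCCCNCC(=O)Nc1cccc2c1CN(C)CC2c1ccccc1` keeps the core but carries (butylamino)methyl in place of benzyloxy on a carbonyl carbon. Going by the values given here, the measured step is only a loose guide, since no measured compound carries (butylamino)methyl and the whole benzyloxy group leaves here. It does show that the number in this assay responds to a change in this part of the molecule. Compound 1, which lacks the ring of benzyloxy, gives the lower number, 3.2 mg/kg, so a modest move towards a lower number is expected, with wide uncertainty. The expected change is a 2.5-fold lower number from compound 2 to compound 3 (0.40 log units; beyond the scatter). Compound 3 is estimated at 6 mg/kg, with an expected range from 1.5 mg/kg to 25 mg/kg.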

Compound 3, dose for half-maximal effect: 32 mg/kg
Estimate against measurement, compound 3: 5.3-fold (0.73 log units) below, and the stated range ends below it.
By their numbers in this assay, from the lowest: compound 1; then compound 2; then compound 3.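

With the third group on this carbonyl carbon, the position now spans a wider range of numbers: in this assay, (butylamino)methyl in place of benzyloxy gives a 2.1-fold higher number from compound 2 to compound 3 (0.33 log units; beyond the scatter) and the same group in place of ethoxy gives a 10-fold higher number from compound 1 to compound 3 (1.00 log units; beyond the scatter). The ring of benzyloxy is therefore not needed for a higher number, since compound 3 has no ring in this group and still has the highest number of the three, which means it needs the largest dose. No measured information is available to explain this shift.

The compounds shown leave open whether the higher number goes with the butyl chain or with the amine nitrogen of (butylamino)methyl. Aminomethyl, which keeps the nitrogen without the butyl chain, and plain pentyl, which has a carbon chain with no nitrogen, would separate these two parts if placed on the same carbonyl carbon of the shared core.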